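This account rests on a few compounds, and the source may have more. Where it says the series, first, only, none or still open, it means among the compounds named here.

Working notes on the series. Going by the values given here, compound 2 `Cc1c(C(=O)/C=C/c2ccc(Cl)c(Cl)c2)[n+]([O-])c2ccccc2[n+]1[O-]` stands at the higher end of the two numbers so far: in a functional assay on HL-60 cells (Homo sapiens) for cytotoxicity, with a stated time of 48 h (a higher number here means that more compound is tolerated, a lower number that less compound is tolerated), compound 2 gives 27000 nM, while compound 1 `Cc1c(C(=O)/C=C/c2ccc(Cl)cc2)[n+]([O-])c2ccccc2[n+]1[O-]` gives 11000 nM in this assay. Among the compounds with values here, the only step measured between them, a 2.5-fold higher number from compound 1 to compound 2 (0.39 log units; beyond the scatter), is the single one that bears on the next change. That change, (4-fluorophenyl in place of 3,4-dichlorophenyl on a double-bonded chain carbon bound to a double-bonded chain carbon), leads to compound 3 `Cc1c(C(=O)/C=C/c2ccc(F)cc2)[n+]([O-])c2ccccc2[n+]1[O-]`. It undoes the chloro that was added from compound 1 to compound 2 and further exchanges the remaining chloro for a fluoro; on the removal of the second chloro the step of a 2.5-fold higher number from compound 1 to compound 2 (0.39 log units; beyond the scatter) is expected to be run back, which would place compound 3 near compound 1, and nothing measured here says what the fluoro in place of chloro adds. Compound 3 is therefore expected to give 11000 nM in this assay, within 5000 nM to 25000 nM, a step of a 2.5-fold lower number from compound 2 to compound 3 (0.39 log units; beyond the scatter) estimated from compound 2.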

Compound 3, half-maximal cytotoxic concentration: 4600 nM
For compound 3 the middle estimate is 2.4-fold (0.38 log units) above the measured one; measured number below the stated range.
By their numbers in this assay, from the lowest: compound 3; then compound 1; then compound 2.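

Going by these compounds alone, the fluoro in place of chloro on an aromatic carbon is not a silent exchange in this assay: it carries a step of its own (a 2.4-fold lower number from compound 1 to compound 3 (0.38 log units; beyond the scatter)), which the earlier compounds could not show. Both steps into compound 3 point the same way, so the whole change of 4-fluorophenyl in place of 3,4-dichlorophenyl (a 5.9-fold lower number from compound 2 to compound 3 (0.77 log units; beyond the scatter)) gives the lowest number of the three, and on this aryl group the number moves with the identity of the halogen as well as with the count of chloro groups. No measurement here accounts for these steps. 

The compounds shown leave open where an unsubstituted phenyl would fall relative to the fluoro and chloro compounds. They also leave open what a methoxy group, an amine or a carboxylic acid would do on the same aryl group.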